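The source may hold more compounds than are shown below. What is called first, only, known or untested is meant among the compounds shown, and "the series" means these compounds.

Of the compounds shown here, three built on one shared core have so far been measured in an assay on isolated protein for binding affinity to 5-hydroxytryptamine receptor 5A (Homo sapiens); a lower number here means a stronger inhibitor, a higher number a weaker inhibitor. Compound 1 `CC1NC(NCC2COc3ccccc3O2)=Nc2ccccc21` gives 37 nM. Compound 2 `CC1NC(NCC2COCCO2)=Nc2ccccc21` gives 96 nM, and compound 3 `CC1NC(NC2CCC2)=Nc2ccccc21` gives 122 nM. Among these three numbers compound 2 stands second highest: its value and that of compound 3 lie within the usual scatter of this kind of measurement, whereas compound 1 sits beyond the scatter with the lower number, meaning the stronger binding.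

Compound 4 `CCCCNC1=Nc2ccccc2C(C)N1` has not yet been tested. It differs from compound 2 in a single place: propyl in place of 1,4-dioxan-2-yl on a saturated chain carbon bound to an amine nitrogen. For the measured compounds named here, no pair of measured compounds shows this particular swap, so its effect has to be judged from the spread of the three values already in hand, which all fall within a fairly narrow band. The group that enters has no ring and no hydrogen-bond acceptors, while compound 3, which carries only a small ring at the same position, gives 122 nM, so a modest shift toward a higher number is expected rather than a large one. The expected step of a 1.6-fold higher number from compound 2 to compound 4 (0.19 log units; within the scatter) should lie near the edge of the scatter. Compound 4 is therefore estimated to give 150 nM in this assay, with a range from 60 nM to 400 nM.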

Compound 4, inhibition constant: 189 nM
The estimate for compound 4 lay 1.3-fold (0.10 log units) below the measured number; measured number inside the range.
By their numbers in this assay, from the lowest: compound 1; then compounds 2, 3 and 4 (each within the scatter of the next).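

For the compounds shown here, until now, no pair of compounds showed what a single swap at this position does. In this assay, propyl in place of 1,4-dioxan-2-yl gives a 2.0-fold higher number from compound 2 to compound 4 (0.29 log units; within the scatter), so losing this ring and its hydrogen-bond acceptors does not separate the two numbers beyond the usual noise of the measurement. Butyl in place of cyclobutyl on an amine nitrogen likewise gives a 1.5-fold higher number from compound 3 to compound 4 (0.19 log units; within the scatter), so compounds 2, 3 and 4 cannot be told apart by these steps, and neither a ring nor hydrogen-bond acceptors at this position is shown to be needed for binding at this level; no independent measurement offers an explanation for these results.

On these data alone, what remains open is whether any group at this position can move the number clearly beyond the scatter, as a longer chain, or a chain ending in an amine or a carboxylic acid, might test. A phenyl group in place of propyl on a saturated chain carbon bound to an amine nitrogen would also ask whether a simple aromatic ring there behaves differently from these small groups.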